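One Methyl More on the Chain, Ileum Read-out

The source may report more compounds than this note shows. Statements on the series, on what has been measured and on what is new or still open speak of the compounds shown alone.

Measured so far, in a functional assay on ileum for inhibition of histamine H1 receptor (Cavia porcellus); on this read-out higher numbers stand for weaker inhibition and lower numbers for stronger inhibition:
compound 1, `CCCCN1CCCN(c2nc3ccccc3n2CCOCC)CC1`, gives 8.4 nM
compound 2, `CCCCN1CCN(c2nc3ccccc3n2CCOCC)CC1`, gives 15 nM
compound 3, `CCCCCN1CCCN(c2nc3ccccc3n2CCOCC)CC1`, gives 7.4 nM

Compound 3 differs from compound 1 by methyl in place of hydrogen on a saturated chain carbon, four bonds along the chain from an amine nitrogen in a ring. That change made a step of a 1.1-fold lower number from compound 1 to compound 3 (0.06 log units; within the scatter), so the two compounds cannot be told apart on this read-out. How the core of compound 2 differs from the core of compound 1 is not broken down here; compound 2 has the highest of the three numbers, within the scatter of compound 1 but beyond it relative to compound 3.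

Compound 4, `CCCCCN1CCN(c2nc3ccccc3n2CCOCC)CC1`, is not yet measured. It differs from compound 2 by methyl in place of hydrogen on a saturated chain carbon, four bonds along the chain from an amine nitrogen in a ring, the same change as between compound 1 and compound 3, made at the same place. From compound 2 to compound 4 the step is expected to be a 1.2-fold lower number from compound 2 to compound 4 (0.06 log units; within the scatter), because the step of a 1.1-fold lower number from compound 1 to compound 3 (0.06 log units; within the scatter) stayed within the scatter. Compound 4 is therefore estimated at 13 nM, most likely between 6 nM and 30 nM.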

Compound 4, half-maximal inhibitory concentration: 30 nM
Beside the measured number, compound 4's estimate is 2.3-fold (0.36 log units) below it; the range from low to high includes it.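

In this assay, the same methyl in place of hydrogen, carried over to the second core, gave a 2.0-fold higher number from compound 2 to compound 4 (0.30 log units; within the scatter). Set beside the earlier step, the result does not separate the two cores: the same change on two cores in this assay, a 1.1-fold lower number (0.06 log units; within the scatter) from compound 1 to compound 3 and a 2.0-fold higher number (0.30 log units; within the scatter) from compound 2 to compound 4, 2.3-fold (0.36 log units) apart, within the scatter of two such steps This shows that, on these two pairs, the change can be carried from one core to the other without a difference that can be told from the scatter, but it does not show that the two cores respond identically, since a modest real difference would go unseen and the comparison rests on only two steps.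

From the compounds shown here alone, what a longer chain, or a chain carrying a hydroxyl group or a carboxylic acid, would do on either core remains open. Going by these compounds, it is also open whether the same agreement would hold on a third core or on any other read-out.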